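A few compounds are considered here, and "the series" means these few. Any claim that something is new, unique, unknown or untested is made for them only; others in the source may bear on it.

Of the compounds shown here, three have been measured in an assay on HEK293 cells for positive allosteric modulation of metabotropic glutamate receptor 2 (Rattus norvegicus), read by thallium flux, with a stated time of 2.5 min; a lower number here means a smaller maximal response, a higher number a larger maximal response. Compound 1, `COC(=O)c1ccc(OCCCCOc2ccc(C(=O)CC3CCCC3)c(O)c2C)cc1`, gives 12.2%. Compound 2, `CCCC(=O)c1ccc(OCCCCOc2cc(C(=O)O)ccc2OC)c(C)c1O`, gives 82.8%. Compound 3, `Cc1c(OCCCCOc2ccc(C(=O)O)c(Cl)c2)ccc(C(=O)CC(C)C)c1C`, gives 33.1%. Among these three numbers compound 2 stands highest: compound 3 comes nearest, its number lower by a margin beyond the usual scatter, and compound 1 lies furthest below, again beyond the scatter.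

The next compound, compound 4, `COc1ccc(C(=O)O)cc1OCCCCOc1ccc(C(=O)CC(C)C)c(O)c1C`, has not yet been measured in this assay. Its structure differs from that of compound 2 in one place: methyl in place of hydrogen on a saturated chain carbon bound to two saturated chain carbons. Cut one bond further out, the same change reads as propyl to isobutyl, or propylcarbonyl to isobutylcarbonyl.

Going by the values given here, no measured pair of compounds differs in just this one place, so no measured step shows what such a change does in this assay. Compound 3 carries an isobutylcarbonyl group and gives 33.1%, yet it differs from compound 2 in several other places as well, so its lower number cannot be tied to the methyl alone. With compound 2 the highest of the three, a downward step of moderate size is expected, that is a number 22.8 percentage points lower from compound 2 to compound 4 (beyond the scatter) in this assay. Compound 4 is therefore expected to give about 60%, within a range from 25% to 90%.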

Compound 4, largest response reached (reported as percent of maximum), in percent of the reference or control that the assay uses: 89.7%
Beside the measured number, compound 4's estimate is 29.7 percentage points below it, within the range that was stated.
By their numbers in this assay, from the lowest: compound 1; then compound 3; then compounds 2 and 4 (each within the scatter of the next).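

In this assay, going by these compounds alone, this is the first pair of compounds that differ in only one place, and it gives a number 6.9 percentage points higher from compound 2 to compound 4 (within the scatter). The change from propylcarbonyl to isobutylcarbonyl therefore leaves the maximal response indistinguishable, so a methyl on this saturated chain carbon bound to two saturated chain carbons is tolerated in this pair, with no loss of response that the assay can detect. No accompanying measurement bears on why the response holds, and the result stands as an observation only.

This single step does not show how far the position can be pushed: a longer chain, a phenyl ring or an amine on the same carbon could hold the response or lose it. Nor does it show whether the methyl would be tolerated as well on other versions of the core, as compound 1 and compound 3 each differ from compound 2 in several places and provide no comparable single-change pair.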